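This account rests on a few compounds, and the source may have more. Where it says the series, first, only, none or still open, it means among the compounds named here.

Measured compounds in a physicochemical assay for solubility, read by LC-MS, in phosphate buffer, measured as thermodynamic solubility, with a stated time of 24 h, at pH 7.4; a higher number here means a more soluble compound, a lower number a less soluble compound:

Compound 1 `Cn1cc(-c2cnc3[nH]cc(-c4cccc(F)c4)c3c2)cn1` gives 3000 nM.
Compound 2 `Cn1cc(-c2cnc3[nH]cc(-c4ccc(O)cc4)c3c2)cn1` gives < 3000 nM, which is a limit of this assay and not a number.
Compound 3 `Cn1cc(-c2cnc3[nH]cc(C4CCCNC4)c3c2)cn1` gives 1000000 nM.

Compound 3 stands highest of the numbers shown: the step of a 330-fold higher number from compound 1 to compound 3 (2.52 log units; beyond the scatter) is large, and the step of an at least 330-fold higher number from compound 2 to compound 3 (2.52 log units; beyond the scatter) is large as well, while the step of a number no higher from compound 1 to compound 2 (the limit leaves the size open) leaves its size open because compound 2 sits at the limit (the limit of < 3000 nM in this assay, at which 1 of the 3 values shown sits). Compound 4 `c1nc2[nH]cc(C3CCCNC3)c2cc1-c1cnn(C2CCOCC2)c1` differs from compound 3 in one place: oxan-4-yl in place of methyl on an aromatic nitrogen. Going by the values given here, none of the measured steps touches this place; all of them exchange the group on an aromatic carbon, and they say nothing about the substituent on the aromatic nitrogen. Among the compounds with values here, with no measured step bearing on it, the expectation for this assay is a step of a 1.7-fold lower number from compound 3 to compound 4 (0.22 log units; within the scatter), that is, no change beyond the scatter, with the number for compound 4 estimated at 600000 nM, within a range of 150000 nM to 1500000 nM.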

Compound 4, solubility: 680000 nM
The estimate for compound 4 lay 1.1-fold (0.05 log units) below the measured number; the measured number falls inside the stated range.
By their numbers in this assay, from the lowest: compound 1; then compounds 4 and 3 (each within the scatter of the next).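

In this assay, the step of a 1.5-fold lower number from compound 3 to compound 4 (0.17 log units; within the scatter) is the first measured change on the aromatic nitrogen, and the earlier steps, all on an aromatic carbon, had shown nothing about this place. With the piperidin-3-yl kept in place, methyl gives way to the much larger oxan-4-yl, which brings a six-membered non-aromatic ring and an oxygen, and the read-out does not separate the two compounds. Nothing in the evidence at hand bears on this result.

The compounds shown leave open whether an amine or a carboxylic acid on the same aromatic nitrogen would also stay within the scatter. They also leave open whether oxan-4-yl would do the same with the 3-fluorophenyl of compound 1 on the aromatic carbon, in place of the piperidin-3-yl.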